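From 2-methoxyethoxy to propylsulfanyl on an aromatic carbon

A few compounds are considered here, and "the series" means these few. Any claim that something is new, unique, unknown or untested is made for them only; others in the source may bear on it.

Three compounds have numbers in a functional assay on MV4-11 cells (Homo sapiens) for inhibition, read by resazurin assay, with a stated time of 72 h (on this read-out higher numbers stand for weaker inhibition of growth and lower numbers for stronger inhibition of growth), so far. Compound 1 `COc1ccc(Nc2nccc(-c3c[nH]c4ccccc34)n2)c(OC(F)F)c1` gives 4770 nM here and compound 2 `Oc1ccccc1Nc1nccc(-c2c[nH]c3ccccc23)n1` gives 570 nM here. Compound 3 `COCCOc1nc(C)c(-c2ccnc(Nc3ccc(OC)cc3OC)n2)s1` gives 1980 nM here, the second highest of the three numbers, and its gaps to both of the others lie beyond the scatter.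

Compound 4 `CCCSc1nc(C)c(-c2ccnc(Nc3ccc(OC)cc3OC)n2)s1` has not yet been measured. It carries propylsulfanyl in place of 2-methoxyethoxy on an aromatic carbon. Among the measured compounds shown here, no two measured compounds differ in one place only, so the data offer no direct guide to this change, and the expectation starts from compound 3 at 1980 nM in this assay. A step beyond the scatter is not expected, with a slight lean toward a lower number. The expected step runs a 1.3-fold lower number from compound 3 to compound 4 (0.12 log units; within the scatter) in this setting. Compound 4 is expected at 1500 nM in this assay with an estimated range from 500 nM to 4500 nM as its bounds.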

Compound 4, concentration for 50% growth inhibition: 2240 nM
Beside the measured number, compound 4's estimate is 1.5-fold (0.17 log units) below it; measured number inside the range.
By their numbers in this assay, from the lowest: compound 2; then compounds 3 and 4 (each within the scatter of the next); then compound 1.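

In this assay, among the compounds shown here, compounds 3 and 4 form the first pair that differs in one place, and propylsulfanyl in place of 2-methoxyethoxy gives a 1.1-fold higher number from compound 3 to compound 4 (0.05 log units; within the scatter). At this aromatic carbon, next to the ring nitrogen and next to the ring sulfur, a chain carrying oxygen and a chain carrying sulfur therefore cannot be told apart on this read-out. Nothing at hand explains why the two compounds lie so close together.

On these data alone, whether an amine, a carboxylic acid or a much longer chain on this carbon would stay within the scatter of these two compounds remains open, as this single pair covers only two neutral chains. Also open, as far as these compounds go, is whether the same exchange would read alike with the other groups of the shared core altered.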